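The source may hold more compounds than are shown below. What is called first, only, known or untested is meant among the compounds shown, and "the series" means these compounds.

Compound 2 `COC(=O)[C@@]1(C)CCC=C2[C@@H]1CC[C@@H](C)[C@]2(C)Cc1c[nH]c2ccc(OC)cc12` carries a methoxy group on the indole portion of a shared core, and compound 1 `COC(=O)[C@@]1(C)CCC=C2[C@@H]1CC[C@@H](C)[C@]2(C)Cc1c[nH]c2ccc(Cl)cc12` carries a chloro group at the same position. Within the data shown here, in a functional assay on WiDr cells (Homo sapiens) for inhibition, read by sulforhodamine B assay, with a stated time of 48 h (a lower number here means a stronger inhibitor of growth, a higher number a weaker inhibitor of growth), compound 1 gives 20000 nM, while compound 2 gives 5700 nM, the lower of the two numbers measured, with compound 1 as its only neighbour. Among the measured compounds shown here, the single measured step, a 3.5-fold lower number from compound 1 to compound 2 (0.55 log units; beyond the scatter), is modest but beyond the scatter.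

Compound 3 `COC(=O)[C@@]1(C)CCC=C2[C@@H]1CC[C@@H](C)[C@]2(C)Cc1c[nH]c2ccc(C(F)(F)F)cc12` is the next variation on the same position: trifluoromethyl in place of methoxy on an aromatic carbon. For the measured compounds named here, no measured step replaces methoxy by trifluoromethyl, so the only guide is the step from compound 1 to compound 2, in which an alternative to methoxy at this carbon gave a higher number. On that basis a move away from methoxy in compound 3 is expected to push the number in this assay upward again, by a step of a 2.6-fold higher number from compound 2 to compound 3 (0.42 log units; beyond the scatter), although the size rests on one comparison only. Compound 3 is therefore estimated at 15000 nM, with a range from 5000 nM to 45000 nM.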

Compound 3, concentration for 50% growth inhibition: 18000 nM
Estimate against measurement, compound 3: 1.2-fold (0.08 log units) below, within the range that was stated.
By their numbers in this assay, from the lowest: compound 2; then compounds 3 and 1 (each within the scatter of the next).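

In this assay, among these compounds, the step from methoxy to trifluoromethyl is a 3.2-fold higher number from compound 2 to compound 3 (0.50 log units; beyond the scatter), so chloro is no longer the only group at this aromatic carbon that gives a higher number than methoxy. The swap between the two non-methoxy groups, a 1.1-fold lower number from compound 1 to compound 3 (0.05 log units; within the scatter), leaves them indistinguishable in this assay, so methoxy alone stands apart among the three groups, and compound 2 is the strongest inhibitor of growth of the three. The data offered here include no measurement that would explain why methoxy differs from chloro and trifluoromethyl at this carbon.

Among the compounds shown here, with only three groups at this carbon, it remains open whether the lower number is peculiar to methoxy or is shared by other groups attached through oxygen, such as hydroxy or the longer ethoxy, or by a group attached through nitrogen, such as an amine. As far as these compounds go, it is also open whether methoxy would give a step of similar size on another carbon of the same six-membered aromatic ring, or on the same carbon with a different shared core.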